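Series notes: microsomal half-life across four analogues

The compounds below may be only part of what the source reports. "The series", "measured", "known", "first", "only" and "open" are said of these compounds alone.

Measured in an ADME assay on microsomes from liver (Homo sapiens) for metabolic stability, read by LC-MS, using NADPH, tested at 3 uM; on this read-out higher numbers stand for a longer-lived compound and lower numbers for a shorter-lived compound:
compound 1 `Cc1ccc2c(C(CC(F)(F)F)c3ccccc3)c(-c3ccccc3)[nH]c2c1` gives 1.45 h
compound 2 `Cc1ccc2c(C(CC(F)(F)F)c3cccs3)c(-c3ccccc3)[nH]c2c1` gives 1.8 h
compound 3 `FC(F)(F)CC(c1cccs1)c1c(-c2ccccc2)[nH]c2cc(Cl)ccc12` gives 2.62 h

The three values lie within the scatter of one another, so no order among them is claimed. Two single-point changes connect them. From compound 2 to compound 1 the change is phenyl in place of thiophen-2-yl on a saturated chain carbon bound to an aromatic carbon and a saturated chain carbon and it gives a 1.2-fold lower number from compound 2 to compound 1 (0.09 log units; within the scatter). From compound 2 to compound 3 the change is chloro in place of methyl on an aromatic carbon and it gives a 1.5-fold higher number from compound 2 to compound 3 (0.16 log units; within the scatter); this is the only difference between the core of compound 2 and the core of compound 3.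

Compound 4 `FC(F)(F)CC(c1ccccc1)c1c(-c2ccccc2)[nH]c2cc(Cl)ccc12` has not been measured in this assay. It differs from compound 3 by phenyl in place of thiophen-2-yl on a saturated chain carbon bound to an aromatic carbon and a saturated chain carbon, which is the same change as that from compound 2 to compound 1, made here on the core of compound 3. Compound 4 is expected to show a 1.2-fold lower number from compound 3 to compound 4 (0.08 log units; within the scatter). That expectation rests on the matching earlier step, a 1.2-fold lower number from compound 2 to compound 1 (0.09 log units; within the scatter), which stayed within the scatter, so the number for compound 4 is expected close to that of compound 3. Compound 4 is estimated at 2.2 h, with a range from 1.3 h to 3.8 h.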

Compound 4, half-life: 1.64 h
Beside the measured number, compound 4's estimate is 1.3-fold (0.13 log units) above it; low and high end bracket the measured number.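

In this assay, phenyl in place of thiophen-2-yl gives a 1.6-fold lower number from compound 3 to compound 4 (0.20 log units; within the scatter), and the change reads alike on the two cores: the same change on two cores in this assay, a 1.2-fold lower number (0.09 log units; within the scatter) from compound 2 to compound 1 and a 1.6-fold lower number (0.20 log units; within the scatter) from compound 3 to compound 4, 1.3-fold (0.11 log units) apart, within the scatter of two such steps

Chloro in place of methyl gives a 1.1-fold higher number from compound 1 to compound 4 (0.05 log units; within the scatter), and this change also reads alike on the two cores: the same change on two cores in this assay, a 1.5-fold higher number (0.16 log units; within the scatter) from compound 2 to compound 3 and a 1.1-fold higher number (0.05 log units; within the scatter) from compound 1 to compound 4, 1.3-fold (0.11 log units) apart, within the scatter of two such steps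

Both changes therefore carry from one core to the other with no difference that stands out from the scatter, but each step is itself within the scatter, so the four compounds do not show that either change has a real effect on half-life, or that a step of a fixed size transfers between cores.

The compounds shown leave open whether a larger step would appear with a different group on the saturated chain carbon bound to an aromatic carbon and a saturated chain carbon, such as a pyridine ring or a cyclohexyl ring. They also leave open how half-life would respond to a nitrile or a methoxy group in place of the chloro.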